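The source may report more compounds than this note shows. Statements on the series, on what has been measured and on what is new or still open speak of the compounds shown alone.

Compound 1, `NS(=O)(=O)c1ccc(/N=C2\NC(=O)/C(=C3/C(=O)Nc4ccccc43)S2)cc1`, is the unsubstituted parent of this set. In a functional assay on Caco-2 cells (Homo sapiens) for antiproliferative activity, read by MTT assay (on this read-out higher numbers stand for weaker inhibition and lower numbers for stronger inhibition), compound 1 gives only a limit, > 200000 nM. Compound 3, `NS(=O)(=O)c1ccc(/N=C2\NC(=O)/C(=C3/C(=O)N(Cc4ccccc4)c4ccccc43)S2)cc1`, carries benzyl in place of hydrogen on an amide-type nitrogen in a ring and also gives only a limit, > 200000 nM. The step that the two limits leave unreadable from compound 1 to compound 3 is unreadable because both values sit at the limit of > 200000 nM in this assay, at which 2 of the 3 values shown sit. Compound 2, `NS(=O)(=O)c1cccc(/N=C2\NC(=O)/C(=C3/C(=O)Nc4ccc(Br)cc43)S2)c1`, differs from compound 1 in two places, with bromo and a differently placed sulfonamide. In this assay, for the measured compounds named here, compound 2 gives 10800 nM, the one numbered value in the set. Compound 4, `NS(=O)(=O)c1ccc(/N=C2\NC(=O)/C(=C3/C(=O)Nc4ccc(Cl)cc43)S2)cc1`, differs from compound 1 by chloro in place of hydrogen on an aromatic carbon. Going by the values given here, no measured step covers this change alone. The step of an at least 4.0-fold lower number from compound 1 to compound 4 (0.60 log units; beyond the scatter) is expected to go toward stronger inhibition, its size uncertain. For compound 4 the estimate is 50000 nM, within 8000 nM to 200000 nM.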

Compound 4, half-maximal inhibitory concentration: 20300 nM
Compound 4: middle estimate off by 2.5-fold (0.39 log units), on the high side, and the stated range covers the measured number.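

In this assay, for the compounds shown here, chloro in place of hydrogen on an aromatic carbon gives an at least 9.8-fold lower number from compound 1 to compound 4 (0.99 log units; beyond the scatter), the first readable single-change step. A change at this carbon of the fused system therefore moves the number toward stronger inhibition, which the benzyl change on the amide-type nitrogen did not show. The step stays a lower bound because compound 1 gives only a limit: the limit of > 200000 nM in this assay, at which 2 of the 4 values shown sit.

From the compounds shown here alone, whether fluoro, methoxy or an amine at this carbon would move the number the same way stays open. Going by these compounds, the effect of bromo alone at this carbon, with the sulfonamide placement held fixed, also stays open.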